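The source may hold more compounds than are shown below. What is called first, only, known or untested is meant among the compounds shown, and "the series" means these compounds.

In a functional assay on A549 cells (Homo sapiens) for inhibition, read by MTT assay, with a stated time of 48 h (on this read-out higher numbers stand for weaker inhibition and lower numbers for stronger inhibition), three compounds built on a shared core have been measured. Compound 1 (`COc1cc(/C=N/Nc2nc(-c3cccc(Br)c3)cs2)cc(Br)c1OC`) gives 56000 nM, compound 2 (`Fc1ccc(/C=N/Nc2nc(-c3ccc(F)c(F)c3)cs2)cc1F`) gives 8490 nM, and compound 3 (`COc1ccccc1-c1csc(N/N=C/c2ccc(F)c(F)c2)n1`) gives 61300 nM. Compound 3 and compound 1 lie within the usual scatter of each other, and both numbers sit well above that of compound 2.

Compound 4 (`Fc1ccc(/C=N/Nc2nc(-c3ccc(Br)cc3)cs2)cc1F`) keeps the rest of compound 3 and exchanges one group: 4-bromophenyl in place of 2-methoxyphenyl on an aromatic carbon. Among the measured compounds shown here, only one measured step changes this same place, a 7.2-fold higher number from compound 2 to compound 3 (0.86 log units; beyond the scatter), where 2-methoxyphenyl replaces 3,4-difluorophenyl. Read backwards, it suggests that losing 2-methoxyphenyl in favour of a halogen-bearing phenyl group could lower the number. Compound 1 urges caution, since it also carries bromine on the phenyl group at this place and gives 56000 nM, although it differs on the other side of the molecule as well. For the measured compounds named here, no compound with 4-bromophenyl has been measured yet. A step towards stronger inhibition is therefore expected, but probably only part of the size seen between compound 2 and compound 3. The estimate amounts to a 3.4-fold lower number from compound 3 to compound 4 (0.53 log units; beyond the scatter). For compound 4 the expected value is 18000 nM, within an estimated range of 6000 nM to 55000 nM.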

Compound 4, half-maximal inhibitory concentration: > 100000 nM
Compound 4 ended at the assay's limit; the forecaster's own chance of this, stated with the estimate: 3%; at least 5.5-fold (0.74 log units) between middle value and limit.
By their numbers in this assay, from the lowest: compound 2; then compounds 1 and 3 (each within the scatter of the next). At a limit, above all of these: compound 4.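

The value of compound 4 in this assay is a limit of the assay and not a number: the limit of > 100000 nM in this assay, at which 1 of the 4 values shown sits.

This limit means the change from 2-methoxyphenyl to 4-bromophenyl can be read only as a floor, an at least 1.6-fold higher number from compound 3 to compound 4 (0.21 log units; that floor lies within the scatter), so the data do not firmly separate these two groups at this position. The comparison with the 3,4-difluorophenyl group is clearer, with an at least 11-fold higher number from compound 2 to compound 4 (1.07 log units; beyond the scatter), which shows that a halogen on this phenyl group does not by itself keep the number low. With the rest of the molecule held constant across compound 2, compound 3 and compound 4, the 3,4-difluorophenyl group of compound 2 gives the lowest number, and both other groups sit far from it.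

On these data alone, it remains open whether the result for compound 2 depends on fluorine rather than bromine, or on having two halogens rather than one, and a 4-fluorophenyl group at this place would help separate those two readings. As far as these compounds go, it is also open how a phenyl group with no substituent, or one carrying an amine or a carboxylic acid, would behave here.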